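The source may hold more compounds than are shown below. What is called first, only, known or untested is meant among the compounds shown, and "the series" means these compounds.

Measured in a physicochemical assay for solubility; on this read-out higher numbers stand for higher solubility and lower numbers for lower solubility:
compound 1 `C[C@H](Oc1ccc(S(C)(=O)=O)cc1C(=O)N1Cc2cc(C(F)(F)F)cnc2C1)C(F)(F)F` gives 280 ug/mL
compound 2 `C[C@H](Oc1ccc(S(C)(=O)=O)cc1C(=O)N1Cc2cnc(C(F)(F)F)cc2C1)C(F)(F)F` gives 470 ug/mL
compound 3 `CC(C)Oc1ccc(S(C)(=O)=O)cc1C(=O)N1Cc2cc(C(F)(F)F)cnc2C1` gives 114 ug/mL

Compound 3 (114 ug/mL) stands lowest of the three, and the gaps to compound 1 and compound 2 both lie beyond the scatter. Compound 4 `CC(C)COc1ccc(S(C)(=O)=O)cc1C(=O)N1Cc2cc(C(F)(F)F)cnc2C1` has yet to be measured. It differs from compound 3 in one place: isobutyl in place of isopropyl on an oxygen on an aromatic ring, or isopropoxy to isobutoxy.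

For the measured compounds named here, only one measured step involves this oxygen (a 2.5-fold lower number from compound 1 to compound 3 (0.39 log units; beyond the scatter)). It is modest, and it swaps a different group, so it offers a guide to size only. Going by the values given here, no measured compound carries isobutyl, which leaves the direction a judgement. A modest move to a lower number is expected, similar in size to that step (a 1.6-fold lower number from compound 3 to compound 4 (0.21 log units; within the scatter)). Compound 4 is estimated at 70 ug/mL (expected range 30 ug/mL to 150 ug/mL).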

Compound 4, solubility: 445 ug/mL
The estimate for compound 4 lay 6.4-fold (0.80 log units) below the measured number, and the stated range ends below it.
By their numbers in this assay, from the lowest: compound 3; then compounds 1, 4 and 2 (each within the scatter of the next).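

In this assay, for the compounds shown here, the swap of isopropoxy to isobutoxy gives a 3.9-fold higher number from compound 3 to compound 4 (0.59 log units; beyond the scatter), the first step at this oxygen that ends on a higher number, whereas the earlier step gave a 2.5-fold lower number from compound 1 to compound 3 (0.39 log units; beyond the scatter). Alkyl groups on this oxygen that differ by a single carbon can therefore lie beyond the scatter of each other, so the position is sensitive to small changes in the chain. Isobutyl, which carries no fluorine, set against 1-(trifluoromethyl)ethyl gives a 1.6-fold higher number from compound 1 to compound 4 (0.20 log units; within the scatter), which lies within the scatter, so the trifluoromethyl-bearing group is not needed to reach that level on this core, and nothing measured here explains either step.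

On these data alone, it remains open whether a longer chain such as n-pentyl, or a methoxyethyl group, would hold this level. As far as these compounds go, it is also open whether isobutyl on the core of compound 2 would behave in the same way.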